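A few compounds are considered here, and "the series" means these few. Any claim that something is new, unique, unknown or untested is made for them only; others in the source may bear on it.

Measured compounds:
- Compound 1, `CC(C)(C)C1=NN(c2ccc(Br)cc2)C(c2ccc(O)cc2)C1`, gives 11400 nM in an assay on isolated protein for inhibition of protein kinase C zeta type (Homo sapiens), with a stated time of 4 min; on this read-out lower numbers stand for stronger inhibition and higher numbers for weaker inhibition.
- Compound 2, `CC(C)(C)C1=NN(c2cccc(F)c2)C(c2ccc(O)cc2)C1`, gives 2200 nM in this assay.
- Compound 3, `CC(C)(C)C1=NN(c2cccc(C(F)(F)F)c2)C(c2ccc(O)cc2)C1`, gives 2700 nM in this assay.

Compound 3 holds the second highest of the three numbers in this assay. Its nearest neighbour is compound 2, whose number lies within the usual scatter of it; its furthest is compound 1, whose number lies beyond the scatter on the higher side.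

Compound 4, `Cc1cccc(N2N=C(C(C)(C)C)CC2c2ccc(O)cc2)c1`, is the next member and differs from compound 3 in one place: methyl in place of trifluoromethyl on an aromatic carbon. Two measured steps are available. The step of a 5.2-fold lower number from compound 1 to compound 2 (0.71 log units; beyond the scatter) changed the whole aryl group on the ring nitrogen and so bears only loosely on the present change. The step of a 1.2-fold higher number from compound 2 to compound 3 (0.09 log units; within the scatter) exchanged one substituent for another at the same aromatic carbon that is now varied, and it stayed within the scatter. On that basis no step beyond the scatter is expected in this assay for the exchange of trifluoromethyl for methyl, in either direction.

Compound 4 is accordingly estimated at 2500 nM, with a range from 1000 nM to 6500 nM. The step this estimate implies, a 1.1-fold lower number from compound 3 to compound 4 (0.03 log units; within the scatter), is expected to remain within the scatter.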

Compound 4, half-maximal inhibitory concentration: 3500 nM
Estimate against measurement, compound 4: 1.4-fold (0.15 log units) below; the range from low to high includes it.
By their numbers in this assay, from the lowest: compounds 2, 3 and 4 (each within the scatter of the next); then compound 1.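

Methyl now joins fluoro and trifluoromethyl on this aromatic carbon, and in this assay the exchange of trifluoromethyl for methyl gives a 1.3-fold higher number from compound 3 to compound 4 (0.11 log units; within the scatter) and that of fluoro for methyl gives a 1.6-fold higher number from compound 2 to compound 4 (0.20 log units; within the scatter) in the same series, so this read-out does not separate the three groups, even though trifluoromethyl has 4 heavy atoms and methyl has 1. A second replacement of the 4-bromophenyl group on the ring nitrogen, by 3-methylphenyl, gives a 3.3-fold lower number from compound 1 to compound 4 (0.51 log units; beyond the scatter) and runs in the same direction as a 5.2-fold lower number from compound 1 to compound 2 (0.71 log units; beyond the scatter) in the earlier pair, so two different replacements of that group now lower the number beyond the scatter. Nothing available gives a reason for either the flat response at this carbon or the difference from the 4-bromophenyl compound.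

As far as these compounds go, whether an amine, a carboxylic acid or a longer chain on this aromatic carbon would stay within the same narrow band remains open. Also open, from the compounds shown here alone, is whether a methyl, fluoro or trifluoromethyl group placed on a different carbon of this aromatic ring would give similar numbers.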